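Methyl for Chloro on the Acid Compound 1

The source may report more compounds than this note shows. Statements on the series, on what has been measured and on what is new or still open speak of the compounds shown alone.

Compound 1 `C=C(C)C(=O)c1ccc(OCC(=O)O)cc1Cl` is the weakest-defined point of the set: in a functional assay on HL-60 cells (Homo sapiens) for antiproliferative activity, with a stated time of 72 h (a lower number here means a stronger inhibitor of growth, a higher number a weaker inhibitor of growth), compound 1 gives only a limit, > 60000 nM. That single value is the one of the three that sits at the limit of > 60000 nM in this assay, at which 1 of the 3 values shown sits. Compound 2 `C=C(CC)C(=O)c1ccc(OC(C)C(=O)OC)c(C)c1C` gives 4600 nM in this assay, and compound 3 `C=C(CC)C(=O)c1ccc(OCC(=O)OC)c(Cl)c1Cl` gives 3900 nM, the two lying within the usual scatter of each other. Compound 4 `C=C(C)C(=O)c1ccc(OCC(=O)O)cc1C` has not been measured. It differs from compound 1 by methyl in place of chloro on an aromatic carbon. Going by the values given here, no measured pair differing in one place is available, so the step of a number no higher from compound 1 to compound 4 (the limit leaves the size open) is expected to be none beyond the scatter. Compound 4 is therefore estimated at 60000 nM, with a range from 20000 nM to 200000 nM, and a limit rather than a number is the more likely outcome.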

Compound 4, concentration for 50% growth inhibition: > 60000 nM
Compound 4: no number, only a limit; the forecaster's own chance of this, stated with the estimate: 75%; the middle value sits exactly at the limit.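

No step can be read between compound 1 and compound 4, since both give only a limit: the limit of > 60000 nM in this assay, at which 2 of the 4 values shown sit.

The compounds shown leave open whether methyl in place of chloro on an aromatic carbon changes growth inhibition on the shared core at all.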